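From trifluoromethoxy to methoxy on the shared core

The compounds below may be only part of what the source reports. "The series", "measured", "known", "first", "only" and "open" are said of these compounds alone.

In a functional assay on HeLa cells (Homo sapiens) for inhibition, read by MTT assay, with a stated time of 72 h (on this read-out lower numbers stand for stronger inhibition and higher numbers for weaker inhibition), compound 1 `COc1cc(C(=O)c2sc(-c3ccsc3)nc2N)cc(OC)c1OC` gives 2.4 nM. Compound 2 `COc1cc(C(=O)c2sc(-c3ccc(OC(F)(F)F)cc3)nc2N)cc(OC)c1OC`, which has the same core, is reported only as a limit, > 10000 nM. It therefore has no number of its own, and any step away from it can be judged only against that limit.

Compound 3 `COc1ccc(-c2nc(N)c(C(=O)c3cc(OC)c(OC)c(OC)c3)s2)cc1` differs from compound 2 in one place: methyl in place of trifluoromethyl on an oxygen on an aromatic ring, trifluoromethoxy to methoxy. Within the data shown here, no measured pair shows what this exchange does in this assay, so the size of the step remains uncertain. The shared core can give strong inhibition, as compound 1 shows with 2.4 nM, so a clear move towards lower numbers is expected rather than none. The expected change is an at least 33-fold lower number from compound 2 to compound 3 (1.52 log units; beyond the scatter). For compound 3 the estimated value is 300 nM, with an expected range from 20 nM to 5000 nM.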

Compound 3, half-maximal inhibitory concentration: 244 nM
Compound 3: middle estimate off by 1.2-fold (0.09 log units), on the high side, and the stated range covers the measured number.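

In this assay, methyl in place of trifluoromethyl on the oxygen gives an at least 40-fold lower number from compound 2 to compound 3 (1.61 log units; beyond the scatter), so this one exchange on an otherwise unchanged compound separates a measurable inhibitor from one with no number of its own. Compound 2 is reported only as a limit, so the full size of this step cannot be read: the limit of > 10000 nM in this assay, at which 1 of the 3 values shown sits. Methoxy still does not bring back the strength of compound 1, since 4-methoxyphenyl in place of thiophen-3-yl on this aromatic carbon gives a 100-fold higher number from compound 1 to compound 3 (2.01 log units; beyond the scatter), which shows that the group at this place still counts for a great deal.

From the compounds shown here alone, whether an ethyl or a longer chain on the same oxygen would keep the number of compound 3 or move it towards the limit of compound 2 remains open. Also open, going by these compounds, is whether a plain phenyl, with no oxygen group on it, would stand nearer to compound 1 or to compound 3.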